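The source may hold more compounds than are shown below. What is called first, only, known or untested is meant among the compounds shown, and "the series" means these compounds.

Working notes on the carbamate series. Compound 3 `Cc1nc(S(C)(=O)=O)ccc1Oc1ncnc(OC2CCN(C(=O)O[C@H](C)CF)CC2)c1F` gives the highest of the three numbers recorded so far in a functional assay on isolated protein for inhibition of Glucose-dependent insulinotropic receptor (Homo sapiens), read by HTRF and cAMP accumulation (a lower number here means that less compound is needed, a higher number that more compound is needed for the effect), at 196 nM. Compound 1 `Cc1nc(S(C)(=O)=O)ccc1Oc1ncnc(OC2CCN(C(=O)OC3CCC3)CC2)c1F` gives 13.6 nM in this assay, and compound 2 `Cc1nc(S(C)(=O)=O)ccc1Oc1ncnc(OC2CCN(C(=O)OC(C)(C)C(F)(F)F)CC2)c1F` gives 6.53 nM. The two steps onto compound 3 are both large: a 14-fold higher number from compound 1 to compound 3 (1.16 log units; beyond the scatter) and a 30-fold higher number from compound 2 to compound 3 (1.48 log units; beyond the scatter). Between the other two the step is smaller: a 2.1-fold lower number from compound 1 to compound 2 (0.32 log units; beyond the scatter).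

Compound 4 `CCC1(OC(=O)N2CCC(Oc3ncnc(Oc4ccc(S(C)(=O)=O)nc4C)c3F)CC2)CC1` is the next analogue, not yet measured. The change from compound 3 is 1-ethylcyclopropyl in place of 1-(fluoromethyl)ethyl on an oxygen next to a carbonyl group. This undoes the move to the 1-(fluoromethyl)ethyl group and puts in a group that, like cyclobutyl in compound 1 and 1-methyl-1-(trifluoromethyl)ethyl in compound 2, is larger than 1-(fluoromethyl)ethyl by the counts shown, and like cyclobutyl carries a carbocycle. Both measured steps toward the 1-(fluoromethyl)ethyl group of compound 3 lost strongly, so a large step back in the other direction, toward the numbers of compound 1 and compound 2, is expected in this assay. Whether the 1-ethylcyclopropyl group lands nearer compound 1 or compound 2 cannot be told from the data at hand, which widens the range. The expected step is a 20-fold lower number from compound 3 to compound 4 (1.29 log units; beyond the scatter). Compound 4 is therefore estimated at 10 nM, with a range from 3 nM to 40 nM.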

Compound 4, half-maximal effective concentration: 22 nM
Compound 4: middle estimate off by 2.2-fold (0.34 log units), on the low side; measured number inside the range.
By their numbers in this assay, from the lowest: compound 2; then compounds 1 and 4 (each within the scatter of the next); then compound 3.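

In this assay, putting 1-ethylcyclopropyl on an oxygen next to a carbonyl group gives an 8.9-fold lower number from compound 3 to compound 4 (0.95 log units; beyond the scatter) and so shows that the high number of compound 3 is not shared by every small group at this position, while the comparison with cyclobutyl gives a 1.6-fold higher number from compound 1 to compound 4 (0.21 log units; within the scatter) and leaves these two carbocycle-bearing groups indistinguishable here. The 1-methyl-1-(trifluoromethyl)ethyl group keeps a real lead over the new group, with a 3.4-fold higher number from compound 2 to compound 4 (0.53 log units; beyond the scatter) as the step, and since compound 2 and compound 3 both carry fluorine yet stand at opposite ends of the order while fluorine-free compound 1 and compound 4 lie between them, fluorine alone does not set the number at this position. Nothing at hand gives a reason for any of these differences.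

Open, going by these compounds, is whether a 1-(trifluoromethyl)cyclopropyl group, which joins a carbocycle to the trifluoromethyl of compound 2, would give a lower number than either parent group. Also open is how the mirror-image form of the 1-(fluoromethyl)ethyl group compares, as the single defined stereocentre of compound 3 is the only form shown.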